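Vero cytotoxicity in the series: towards compound 4

This account rests on a few compounds, and the source may have more. Where it says the series, first, only, none or still open, it means among the compounds named here.

Compound 3 `O=C(/C=C/c1ccc([N+](=O)[O-])o1)c1ccc(Br)cc1` stands at the assay limit in an ADME assay on Vero cells (Chlorocebus sabaeus) for cytotoxicity, read by resazurin assay, with a stated time of 72 h; on this read-out higher numbers stand for lower toxicity in this test and lower numbers for higher toxicity in this test: compound 3 gives > 100000 nM, a limit of the assay and not a number. Compound 1 `O=C(/C=C/c1ccc([N+](=O)[O-])o1)c1ccc(-c2ccccc2)cc1` also gives only a limit there, > 100000 nM. Compound 2 `O=C(/C=C/c1ccc([N+](=O)[O-])o1)c1ccc(N2CCNCC2)cc1` likewise gives a limit, > 100000 nM. All three values sit at the limit of > 100000 nM in this assay, at which 3 of the 3 values shown sit, so the steps a step that the two limits leave unreadable from compound 1 to compound 2, a step that the two limits leave unreadable from compound 1 to compound 3 and a step that the two limits leave unreadable from compound 2 to compound 3 cannot be read in size. Compound 4 `CSc1ccc(C(=O)/C=C/c2ccc([N+](=O)[O-])o2)cc1` differs from compound 3 by methylsulfanyl in place of bromo on an aromatic carbon. For the measured compounds named here, no measured step bears on this exchange in readable form; the series so far yields limits only. Compound 4 is therefore expected to sit at the same limit, an estimated 150000 nM (range 50000 nM to 500000 nM), the expected step that the limit leaves unreadable from compound 3 to compound 4 being none beyond the scatter.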

Compound 4, half-maximal cytotoxic concentration: 40700 nM
Compound 4: middle estimate off by 3.7-fold (0.57 log units), on the high side; the whole stated range lies above it.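

Methylsulfanyl on this aromatic carbon gives the first readable number of the series in this assay with an at least 2.4-fold lower number from compound 3 to compound 4 (0.39 log units; beyond the scatter) and an at least 2.4-fold lower number from compound 2 to compound 4 (0.39 log units; beyond the scatter) and an at least 2.4-fold lower number from compound 1 to compound 4 (0.39 log units; beyond the scatter) as steps that are floors only. For the compounds shown here, the group at this place can therefore shift the read-out, which the earlier compounds could not show, all of them being limits: the limit of > 100000 nM in this assay, at which 3 of the 4 values shown sit.

The steps among compounds 1, 2 and 3 stay unreadable. Open, as far as these compounds go, is whether the sulfur matters, which methoxy or a longer alkylsulfanyl chain at this place would test.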